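Chain lengthening on the shared core: propyl to butyl

The compounds below may be only part of what the source reports. "The series", "measured", "known", "first", "only" and "open" are said of these compounds alone.

Measured so far:
Compound 1, `O=C(Nc1nn[nH]n1)c1cccc(-c2ccccc2)n1`, in a functional assay on the whole organism for inhibition, with Rattus norvegicus as the target, at a dose of 10 mg/kg by the oral route (on this read-out higher numbers stand for a stronger effect at the one dose given and lower numbers for a weaker effect), gives 81%.
Compound 2, `CCc1cc(C(=O)Nc2nn[nH]n2)nc(-c2ccccc2)c1`, in this assay gives 85%.
Compound 3, `CCCc1cc(C(=O)Nc2nn[nH]n2)nc(-c2ccccc2)c1`, in this assay gives 85%.

Compound 3 stands level with compound 2 at the digits reported, and together they hold the highest two of the three numbers. Nearest to compound 3 is compound 2, with no change at the digits printed from compound 2 to compound 3 (within the scatter); furthest is compound 1, with a number 4 percentage points higher from compound 1 to compound 3 (within the scatter).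

Compound 4, `CCCCc1cc(C(=O)Nc2nn[nH]n2)nc(-c2ccccc2)c1`, is the next member of the same chain series. Its difference from compound 3: methyl in place of hydrogen on a saturated chain carbon, three bonds along the chain from an aromatic carbon.

Within the data shown here, three steps bear on this change, all lengthenings of the same chain on the same carbon of the shared core: a number 4 percentage points higher from compound 1 to compound 2 (within the scatter), a number 4 percentage points higher from compound 1 to compound 3 (within the scatter) and no change at the digits printed from compound 2 to compound 3 (within the scatter). Each lies within the scatter, and the two later ones in particular show that adding one carbon further out along the chain did not shift the read-out. Adding one more carbon is therefore expected to give no step beyond the scatter in this assay, in either direction.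

For compound 4 the estimate is 84%, with a range from 72% to 93%. This estimate means an expected step of a number 1 percentage points lower from compound 3 to compound 4 (within the scatter).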

Compound 4, a percentage reported as inhibition, in the whole organism at one dose (the size of the read-out at that dose, not a potency): 100%
For compound 4 the middle estimate is 16 percentage points below the measured one; measured number above the stated range.
By their numbers in this assay, from the lowest: compounds 1, 2 and 3 (each within the scatter of the next); then compound 4.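

In this assay, among these compounds, the butyl chain gives the first steps beyond the scatter on this position, with a number 15 percentage points higher from compound 3 to compound 4 (beyond the scatter) and a number 15 percentage points higher from compound 2 to compound 4 (beyond the scatter) alongside a number 19 percentage points higher from compound 1 to compound 4 (beyond the scatter) in the same series. Across compounds 1 to 4 the read-out therefore does not follow chain length evenly: methyl in place of hydrogen three bonds along the chain from an aromatic carbon separates compound 4 from the rest, whereas the same change two bonds along separated compound 3 from compound 2 by no more than the scatter. No measured evidence bears on this step.

A longer chain such as pentyl or hexyl would show whether the higher read-out persists beyond butyl. On these data alone, a branched chain such as isobutyl, or a butyl chain ending in an amine or a carboxylic acid, remains open at this position.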